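The compounds below may be only part of what the source reports. "The series", "measured", "known", "first", "only" and "open" are said of these compounds alone.

Working notes on the series. Compound 1 `Nc1ncc(-c2ccccc2)c(C2CC2)n1` is the member without a substituent at the carbon in question. In a functional assay on CUTLL1 cells (Homo sapiens) for inhibition, read by resazurin assay, with a stated time of 48 h, in the absence of a further agent (on this read-out lower numbers stand for an effect already at smaller amounts and higher numbers for an effect only at larger amounts of compound), compound 1 gives > 100000 nM, which is a limit of the assay and not a number. In this assay compound 2 `COc1ccc(-c2cnc(N)nc2C2CC2)cc1` gives > 100000 nM, again only a limit, so compound 2 has no number to its name. Both measured compounds therefore stand at the same limit, (the limit of > 100000 nM in this assay, at which 2 of the 2 values shown sit).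

Compound 3 `Nc1ncc(-c2ccc(F)cc2)c(C2CC2)n1` follows from compound 2 by one change: fluoro in place of methoxy on an aromatic carbon, fluoro in place of methoxy, para to a large group. For the measured compounds named here, the only measured step that bears on this carbon is a step that the two limits leave unreadable from compound 1 to compound 2, methoxy in place of hydrogen, and its size cannot be read. It offers no size or direction to carry over, yet neither compound 1 nor compound 2 gave a number, so no step beyond the scatter is expected in this assay, and a further limit is the likely result. The expected change is a number no higher from compound 2 to compound 3 (the limit leaves the size open). For compound 3 the estimated value is 100000 nM, with an expected range of 30000 nM to 300000 nM.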

Compound 3, half-maximal effective concentration: > 100000 nM
Compound 3: a limit, no number (the forecaster's own chance of this, stated with the estimate: 85%); the middle value sits exactly at the limit.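

Compound 3, like compound 1 and compound 2, gives only a limit and not a number in this assay, so none of the steps among these three compounds can be read: the limit of > 100000 nM in this assay, at which 3 of the 3 values shown sit. The compounds shown leave open whether hydrogen, methoxy and fluoro at this carbon differ at all in this read-out, and at what concentration any of the three compounds would act.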